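This account rests on a few compounds, and the source may have more. Where it says the series, first, only, none or still open, it means among the compounds named here.

In a functional assay on MCF7 cells (Homo sapiens) for antiproliferative activity, read by CellTiter-Glo, with a stated time of 5 days (on this read-out lower numbers stand for stronger inhibition and higher numbers for weaker inhibition), compound 1 `CC/C(=C(/c1ccc(/C=C/C(=O)O)cc1)c1ccc2nnnn2c1)c1ccccc1` gives > 500 nM as a limit and not a number. For the measured compounds named here, compound 2 `CC/C(=C(/c1ccc(/C=C/C(=O)O)cc1)c1ccc(-c2cscn2)cc1)c1ccccc1` reads 120 nM and holds the only exact number so far. Compound 3 `CC/C(=C(/c1ccc(/C=C/C(=O)O)cc1)c1ccc(-c2cnn(C)c2)cc1)c1ccccc1` keeps the shared core, but on an aromatic carbon of a six-membered aromatic ring of carbon only, para to a large group, 1-methyl-1H-pyrazol-4-yl stands in place of 1,3-thiazol-4-yl 1-methyl-1H-pyrazol-4-yl in place of 1,3-thiazol-4-yl on an aromatic carbon in this one place. Going by the values given here, no measured step speaks to this exchange, and no change beyond the scatter is expected in this assay. The estimated step is a 1.2-fold lower number from compound 2 to compound 3 (0.08 log units; within the scatter) in either direction of that scatter. Compound 3 is expected at 100 nM with an estimated range from 35 nM to 300 nM in this read-out.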

Compound 3, half-maximal inhibitory concentration: 80 nM
Compound 3: the middle estimate sits 1.3-fold (0.10 log units) above what was measured, and the stated range covers the measured number.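

In this assay, 1-methyl-1H-pyrazol-4-yl in place of 1,3-thiazol-4-yl gives a 1.5-fold lower number from compound 2 to compound 3 (0.18 log units; within the scatter). This single step shows that, on this aromatic carbon, one five-membered aromatic ring with 2 hetero atoms can replace another, here with nitrogen instead of sulfur and an added methyl, without a change beyond the scatter.

From the compounds shown here alone, whether a ring-free group at this place, such as an amine or a carboxylic acid, would hold the number stays open. Compound 1 also remains a limit and not a number: the limit of > 500 nM in this assay, at which 1 of the 3 values shown sits.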